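Methyl on the Ring Nitrogen and Agonist Potency

This account rests on a few compounds, and the source may have more. Where it says the series, first, only, none or still open, it means among the compounds named here.

Of the compounds shown here, three have been measured in an in vitro functional assay on SH-SY5Y cells for agonist activity at Neuronal acetylcholine receptor; alpha3/beta4 (Homo sapiens), read by FLIPR and calcium flux; on this read-out higher numbers stand for an effect only at larger amounts of compound and lower numbers for an effect already at smaller amounts. Compound 3 `C1=C(c2cccnc2)C[C@H]2CNC[C@@H]1C2` gives 37 nM, compound 2 `Fc1ccc(C2=CC3CNCC(C2)C3)cn1` gives 99 nM, and compound 1 `CN1C[C@H]2C=C(c3cccnc3)C[C@H](C2)C1` gives 7530 nM. Compound 1 differs from compound 3 in a single place, (methyl in place of hydrogen on an amine nitrogen in a ring), and that change made a step of a 200-fold higher number from compound 3 to compound 1 (2.31 log units; beyond the scatter). How the core of compound 2 differs from the core of compound 3 is not broken down here. Compound 4 `CN1CC2C=C(c3ccc(F)nc3)CC(C2)C1` has not yet been measured; it differs from compound 2 by methyl in place of hydrogen on an amine nitrogen in a ring, the same change at the same place as between compound 3 and compound 1. The step from compound 2 to compound 4 is therefore expected to be a 150-fold higher number from compound 2 to compound 4 (2.18 log units; beyond the scatter), resting on the step of a 200-fold higher number from compound 3 to compound 1 (2.31 log units; beyond the scatter) seen once with this change. Compound 4 is accordingly estimated to give about 15000 nM in this assay.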

Compound 4, half-maximal effective concentration: > 10000 nM
Compound 4: no number, only a limit; the forecaster's own chance of this, stated with the estimate: 20%; the middle value lies beyond the limit too.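

Compound 4 gives > 10000 nM, which is a limit of the assay and not a number. Methyl in place of hydrogen on the amine nitrogen made a step of an at least 100-fold higher number from compound 2 to compound 4 (2.00 log units; beyond the scatter), so on this core too, much more compound is needed for an effect. The change therefore carries over in direction and stays large on both cores, but whether its size is the same on each remains unsettled: the same change on two cores in this assay, a 200-fold higher number (2.31 log units; beyond the scatter) from compound 3 to compound 1 and an at least 100-fold higher number (2.00 log units; beyond the scatter) from compound 2 to compound 4; the limit leaves it open whether they differ

The compounds shown leave open whether an ethyl group or a longer chain on this nitrogen would raise the number as far as methyl does. They also leave open how the change would behave on cores other than these two.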